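Extending a Methyl Group into a Pyridinylmethyl Arm

The source may report more compounds than this note shows. Statements on the series, on what has been measured and on what is new or still open speak of the compounds shown alone.

Going by the values given here, compound 2, `Cn1nc(-c2ccnc(Nc3cccc(S(N)(=O)=O)c3)n2)c2ccccc21`, holds the lower of the two numbers available so far in a functional assay on HCT-116 cells (Homo sapiens) for antiproliferative activity, read by MTT assay, with a stated time of 72 h; a lower number here means a stronger inhibitor of growth, a higher number a weaker inhibitor of growth: in that assay compound 2 gives 1980 nM. Among the compounds with values here, its only measured neighbour is compound 1, `Cn1nc(-c2ccnc(Nc3cccc(O)c3)n2)c2ccccc21`, which in this assay gives 17200 nM; the two are separated by the step of an 8.7-fold lower number from compound 1 to compound 2 (0.94 log units; beyond the scatter). Compound 3, `NS(=O)(=O)c1cccc(Nc2nccc(-c3nn(Cc4cccnc4)c4ccccc34)n2)c1`, has not yet been measured. It differs from compound 2 by pyridin-3-yl in place of hydrogen on a saturated chain carbon bound to an aromatic nitrogen; cut one bond further out, the change reads methyl to (pyridin-3-yl)methyl. Within the data shown here, none of the measured steps touches this place: the single known step, an 8.7-fold lower number from compound 1 to compound 2 (0.94 log units; beyond the scatter), concerns a substituent on an aromatic carbon and says nothing about the saturated chain carbon bound to an aromatic nitrogen. Among the measured compounds shown here, with no precedent inside this set, the step of a 1.7-fold lower number from compound 2 to compound 3 (0.22 log units; within the scatter) is expected to be small, and it could fall on either side of the scatter. Compound 3 is therefore estimated to give about 1200 nM in this assay, with a range from 300 nM to 5000 nM.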

Compound 3, concentration for 50% growth inhibition: 8280 nM
Estimate against measurement, compound 3: 6.9-fold (0.84 log units) below; measured number above the stated range.
By their numbers in this assay, from the lowest: compound 2; then compound 3; then compound 1.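

Going by these compounds alone, at the saturated chain carbon bound to an aromatic nitrogen, the change from methyl to (pyridin-3-yl)methyl gives the first measured reading of this place in this assay, and that reading is a 4.2-fold higher number from compound 2 to compound 3 (0.62 log units; beyond the scatter). The place is therefore not indifferent to substitution: with the sulfamoyl group and the shared core held constant, this single change makes compound 3 a weaker inhibitor of growth than compound 2, so this larger arm does not improve on methyl here. No measurement offered here accounts for the loss.

The compounds shown cannot separate the contribution of the pyridine nitrogen from that of the aromatic ring as a whole, since a plain benzyl group would be needed to draw that distinction. They also leave open how this place responds to a small ethyl group, to a longer chain ending in an amine, or to a carboxylic acid, and whether the same change would have a similar effect with hydroxy in place of sulfamoyl.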